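A few compounds are considered here, and "the series" means these few. Any claim that something is new, unique, unknown or untested is made for them only; others in the source may bear on it.

Compounds with values in hand:
compound 1 `COc1ccc(C(=O)c2cc(OC)c(OC)c(OC)c2)cc1NC(=O)/C=C/c1ccc(C(F)(F)F)cc1` — 800 nM
compound 2 `COc1ccc(/C=C/C(=O)Nc2cc(C(=O)c3cc(OC)c(OC)c(OC)c3)cc(OC)c2OC)cc1OC` — 6700 nM
compound 3 `C#CCOc1cccc(/C=C/C(=O)Nc2cc(C(=O)c3cc(OC)c(OC)c(OC)c3)cc(OC)c2OC)c1` — 8400 nM

In a functional assay on ME-180 cells (Homo sapiens) for cytotoxicity, read by MTT assay, with a stated time of 72 h (a higher number here means a weaker inhibitor, a lower number a stronger inhibitor), compound 3 holds the highest of the three numbers. Its nearest neighbour is compound 2, and the step from compound 2 to compound 3, a 1.3-fold higher number from compound 2 to compound 3 (0.10 log units; within the scatter), stays within the scatter. Compound 1, which is built on a different core, gives a number well below both.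

Compound 4 `COc1cc(C(=O)c2cc(OC)c(OC)c(OC)c2)cc(NC(=O)/C=C/c2ccc(C(F)(F)F)cc2)c1OC` shares the core of compound 3 and differs from it by 4-(trifluoromethyl)phenyl in place of 3-(propargyloxy)phenyl on a double-bonded chain carbon bound to a double-bonded chain carbon. Going by the values given here, only one measured step touches the same place, and that is the step from compound 2 to compound 3, which was small. Among the compounds with values here, compound 1, which carries the same 4-(trifluoromethyl)phenyl on its chain but sits on another core, gives a lower number; no single-point step links it to compound 3, so its value can only be read as a hint.

Weighing the flat step against that hint, compound 4 is expected to come in somewhat below compound 3, a step of about a 2.4-fold lower number from compound 3 to compound 4 (0.38 log units; beyond the scatter), with an estimate of 3500 nM and a range from 900 nM to 12000 nM.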

Compound 4, half-maximal inhibitory concentration: 3600 nM
Beside the measured number, compound 4's estimate is 1.0-fold (0.01 log units) below it, and the stated range covers the measured number.
By their numbers in this assay, from the lowest: compound 1; then compounds 4, 2 and 3 (each within the scatter of the next, the first and the last beyond it).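

In this assay, this chain position now shows a change that clears the scatter: 4-(trifluoromethyl)phenyl in place of 3-(propargyloxy)phenyl gives a 2.3-fold lower number from compound 3 to compound 4 (0.37 log units; beyond the scatter) and so separates two groups at a place where the earlier step had stayed flat. Against 3,4-dimethoxyphenyl the same group gives a 1.9-fold lower number from compound 2 to compound 4 (0.27 log units; within the scatter) and no separation, so the outcome depends on which group it replaces. With the chain group held fixed, methoxy in place of hydrogen on an aromatic carbon gives a 4.5-fold higher number from compound 1 to compound 4 (0.65 log units; beyond the scatter) and shows that the core also moves the number, though no measurement on hand explains either change.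

As far as these compounds go, whether the step comes from the trifluoromethyl group itself remains open, as does how a plain phenyl or a dimethylamino group would read on this chain. Going by these compounds alone, only one chain group spans both cores, so the generality of the methoxy step is also unsettled.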